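The compounds below may be only part of what the source reports. "The series", "measured", "known", "first", "only" and "open" are said of these compounds alone.

Measured compounds in an ADME assay on J774.A1 cells (Mus musculus) for cytotoxicity, read by MTT assay, with a stated time of 72 h; a lower number here means that less compound is tolerated, a higher number that more compound is tolerated:
- compound 1 `Clc1cccc(COC(CCn2cncn2)c2ccco2)c1`: 18600 nM
- compound 3 `Clc1cccc(COC(CCn2ccnc2)c2ccco2)c1`: 60200 nM
- compound 2 `Fc1ccc(COC(CCn2cncn2)c2cccs2)c(F)c1`: "not determined" (no result reported)

Compound 3 carries 1H-imidazol-1-yl in place of 1H-1,2,4-triazol-1-yl on a saturated chain carbon, three bonds along the chain from an aromatic carbon and an oxygen on a saturated carbon relative to compound 1, and this assay gives a 3.2-fold higher number from compound 1 to compound 3 (0.51 log units; beyond the scatter). Compound 4 `Fc1ccc(COC(CCn2ccnc2)c2cccs2)c(F)c1` is not yet measured; it stands to compound 2 as compound 3 stands to compound 1, the change being (1H-imidazol-1-yl in place of 1H-1,2,4-triazol-1-yl on a saturated chain carbon, three bonds along the chain from an aromatic carbon and an oxygen on a saturated carbon). Within the data shown here, the difference between the core of compound 2 and the core of compound 1 is not broken down here, so the only anchor for the step from compound 2 to compound 4 is the single measured pair. Among the measured compounds shown here, compound 4 is therefore expected to be tolerated at a higher concentration than compound 2, a step of roughly the same size as the one from compound 1 to compound 3, with wide uncertainty because compound 2 itself has no number. The estimate for compound 4 in this assay is 55000 nM, expected within 15000 nM to 200000 nM.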

Compound 4, half-maximal cytotoxic concentration: 34400 nM
Compound 4: the middle estimate sits 1.6-fold (0.20 log units) above what was measured, within the range that was stated.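

No new step can be read between compound 2 and compound 4 in this assay, as compound 2 has no number to compare. Whether the change repeats a 3.2-fold higher number from compound 1 to compound 3 (0.51 log units; beyond the scatter) on this core stays open, and no evidence bears on a cause.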